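The source may report more compounds than this note shows. Statements on the series, on what has been measured and on what is new or still open speak of the compounds shown alone.

Three compounds have been measured so far in a functional assay on MCF7 cells (Homo sapiens) for cytotoxicity, read by MTT assay, with a stated time of 72 h; a higher number here means a weaker inhibitor, a lower number a stronger inhibitor:

compound 1 `COc1ccc(/C=C2\CCC/C(=C\c3ccc(Cl)cc3)C2=O)cc1OC` gives 6300 nM
compound 2 `COc1ccc(/C=C2\CCC/C(=C\c3ccccc3Br)C2=O)cc1OC` gives 9500 nM
compound 3 `COc1ccc(/C=C2\CCC/C(=C\c3cccc(Br)c3)C2=O)cc1OC` gives 5300 nM

Compound 3, at 5300 nM in this assay, cannot be ranked apart from the other two. The data show a 1.2-fold lower number from compound 1 to compound 3 (0.08 log units; within the scatter) and a 1.8-fold lower number from compound 2 to compound 3 (0.25 log units; within the scatter), and both steps stay within the scatter.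

Compound 4 `COc1ccccc1/C=C1\CCC/C(=C\c2ccc(OC)c(OC)c2)C1=O` has not yet been measured. It differs from compound 3 in one place, on a double-bonded chain carbon bound to a double-bonded ring carbon, where 2-methoxyphenyl takes the place of 3-bromophenyl: 2-methoxyphenyl in place of 3-bromophenyl on a double-bonded chain carbon bound to a double-bonded ring carbon.

The measured steps that bear on this change are swaps at that same place. Besides the two already given, there is a 1.5-fold higher number from compound 1 to compound 2 (0.18 log units; within the scatter), also within the scatter. Across these three compounds, then, exchanging the aryl group has not moved the number beyond the scatter. None of them carries 2-methoxyphenyl at that place, so the data do not test this group directly. No step beyond the scatter is therefore expected in this assay, and no direction is favoured. The expected change is a 1.2-fold higher number from compound 3 to compound 4 (0.09 log units; within the scatter). Compound 4 is estimated at 6500 nM, with an expected range from 3000 nM to 14000 nM.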

Compound 4, half-maximal inhibitory concentration: 8000 nM
For compound 4 the middle estimate is 1.2-fold (0.09 log units) below the measured one; the measured number falls inside the stated range.
By their numbers in this assay, from the lowest: compounds 3, 1, 4 and 2 (each within the scatter of the next).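

In this assay, for the compounds shown here, compound 4 puts at this place, on a double-bonded chain carbon bound to a double-bonded ring carbon, the first aryl group with an oxygen and no halogen, and with it a hydrogen-bond acceptor that 3-bromophenyl lacks; even so, the change gives a 1.5-fold higher number from compound 3 to compound 4 (0.18 log units; within the scatter) and thus no separation from the bromo compound. The other two new comparisons agree, with methoxy in place of bromo on an aromatic carbon giving a 1.2-fold lower number from compound 2 to compound 4 (0.07 log units; within the scatter) and 2-methoxyphenyl in place of 4-chlorophenyl giving a 1.3-fold higher number from compound 1 to compound 4 (0.10 log units; within the scatter) so that, among these four compounds, a non-halogen group has joined the halogen-bearing ones without any step leaving the scatter. No measurement offered here explains why the number stays so level across these groups.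

The compounds shown leave open whether any group at this place can move the number beyond the scatter, for instance an aryl ring bearing an amine or a carboxylic acid, or a longer chain in place of methoxy. They also leave open what a change would do on the other aryl group of the shared core, which is the same in all four compounds.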